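Difluorophenyl in Place of Dimethylaminophenyl on a Weak Inhibitor

The source may report more compounds than this note shows. Statements on the series, on what has been measured and on what is new or still open speak of the compounds shown alone.

Three compounds have been measured in a functional assay on DU-145 cells (Homo sapiens) for inhibition, read by trypan blue exclusion, with a stated time of 96 h; on this read-out lower numbers stand for stronger inhibition of growth and higher numbers for weaker inhibition of growth:
- compound 1 `CN(C)c1ccc(/C=C(\C(=O)c2ccc(Br)cc2)S(=O)(=O)Cc2ccc(F)cc2)cc1`, which gives 50000 nM
- compound 2 `Cc1ccc(S(=O)(=O)/C(=C/c2ccc(N(C)C)cc2)C(=O)c2ccc(Br)cc2)cc1`, which gives 50000 nM
- compound 3 `Cc1ccc(S(=O)(=O)/C(=C/c2ccc(N(C)C)cc2)C(=O)c2ccc(Cl)cc2)cc1`, which gives > 100000 nM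

The value of compound 3 is a limit of the assay, not a number. Compound 2 stands level with compound 1 at the digits shown, as the step of no change at the digits printed from compound 1 to compound 2 (within the scatter) makes plain, and the step of an at least 2.0-fold higher number from compound 2 to compound 3 (0.30 log units; that floor lies within the scatter) reaches only the floor set by the limit (the limit of > 100000 nM in this assay, at which 1 of the 3 values shown sits).

Compound 4 `Cc1ccc(S(=O)(=O)/C(=C/c2ccc(F)cc2F)C(=O)c2ccc(Br)cc2)cc1` differs from compound 2 in one place: 2,4-difluorophenyl in place of 4-(dimethylamino)phenyl on a double-bonded chain carbon bound to a double-bonded chain carbon. Neither measured step touches this position. The step of no change at the digits printed from compound 1 to compound 2 (within the scatter) concerns the group on the sulfonyl sulfur and the step of an at least 2.0-fold higher number from compound 2 to compound 3 (0.30 log units; that floor lies within the scatter) the halogen on an aromatic carbon, so nothing measured here tells how the aryl group on the double-bonded chain carbon governs this assay. With both measured compounds holding a number sitting at a weak level and one compound at the limit, compound 4 is expected to stay in the same weak region, and the step of a 1.2-fold higher number from compound 2 to compound 4 (0.08 log units; within the scatter) is expected to lie within the scatter. For compound 4 the estimate is 60000 nM, with a range from 25000 nM to 150000 nM, and a fair chance that only a limit is reported.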

Compound 4, concentration for 50% growth inhibition: > 100000 nM
Compound 4: no number, only a limit; the forecaster's own chance of this, stated with the estimate: 35%; middle value at least 1.6-fold (0.22 log units) away from the limit.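

In this assay compound 4 gives > 100000 nM, which is a limit of the assay and not a number. Within the data shown here, the aryl group on the double-bonded chain carbon now has a reading for the first time, and the exchange gives an at least 2.0-fold higher number from compound 2 to compound 4 (0.30 log units; that floor lies within the scatter), so 2,4-difluorophenyl in place of 4-(dimethylamino)phenyl brings no gain in growth inhibition that this read-out can show, while the true size of the step stays unknown. The limit has now been reached through two separate single changes from compound 2, one on the halogen in compound 3 and one on this aryl group in compound 4: the limit of > 100000 nM in this assay, at which 2 of the 4 values shown sit.

The compounds shown leave open whether another group on this double-bonded chain carbon, such as 4-methoxyphenyl, 4-hydroxyphenyl or a pyridine ring, would give a number clearly lower than those of compound 1 and compound 2. They also leave open how 2,4-difluorophenyl would read with chloro in place of bromo on the aromatic carbon, or with 4-fluorobenzyl on the sulfonyl sulfur.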